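Thiophene for pyridine on the shared core, compound 2 to 3

This account rests on a few compounds, and the source may have more. Where it says the series, first, only, none or still open, it means among the compounds named here.

For the measured compounds named here, compound 1 `Oc1cccc(-c2cc(-c3ccsc3)nc(-c3cccc(Cl)c3)c2)c1` is the only member of this set with a number: in a functional assay on DU-145 cells (Homo sapiens) for cytotoxicity, read by CCK-8 assay and cell counting, with a stated time of 2 days (a higher number here means a weaker inhibitor, a lower number a stronger inhibitor), compound 1 gives 3330 nM. Compound 2 `Oc1cccc(-c2cc(-c3ccccn3)nc(-c3ccccc3Cl)c2)c1` carries a pyridin-2-yl group and a 2-chlorophenyl group on the same core; in this assay compound 2 has "not determined" (no result reported), so it stands nowhere on the numbers shown and offers no anchor of its own. Compound 3 `Oc1cccc(-c2cc(-c3ccsc3)nc(-c3ccccc3Cl)c2)c1` is the target of the step. From compound 2 to compound 3 the change is thiophen-3-yl in place of pyridin-2-yl on an aromatic carbon, in words thiophen-3-yl in place of pyridin-2-yl on an aromatic carbon, with the 2-chlorophenyl group and the 3-hydroxyphenyl group kept. Going by the values given here, no measured pair in this set shows this swap, so the size of the step in this assay cannot be read from the data; a step of no more than the usual scatter, in either direction, is the plain expectation. Compound 3 shares the thiophen-3-yl group with compound 1, and its value in this assay is expected to lie near 4000 nM, between 1500 nM and 12000 nM.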

Compound 3, half-maximal inhibitory concentration: 1970 nM
Estimate against measurement, compound 3: 2.0-fold (0.31 log units) above; the range from low to high includes it.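

Compound 2 gives no number in this assay, so the step from pyridin-2-yl to thiophen-3-yl on this aromatic carbon cannot be read, and the result does not show what this swap does. What it adds is a second number with thiophen-3-yl in place: with that group and the 3-hydroxyphenyl group kept, 2-chlorophenyl in place of 3-chlorophenyl gives a 1.7-fold lower number from compound 1 to compound 3 (0.23 log units; within the scatter), so in this assay this pair does not separate the two chlorophenyl groups. No measured data bear on why the values of this pair lie where they do.

The compounds shown leave open how pyridin-2-yl compares with thiophen-3-yl at this position, since that comparison would need a number for a pyridin-2-yl compound that otherwise matches compound 1 or compound 3. For the compounds shown here, they also leave open whether an amine, a carboxylic acid or a longer alkyl chain on this aromatic carbon would give a step beyond the scatter in this assay, as the only group here with a number at this position is thiophen-3-yl.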